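Series notes: the benzyl group on the sulfur arm

The compounds below may be only part of what the source reports. "The series", "measured", "known", "first", "only" and "open" are said of these compounds alone.

Going by the values given here, in an ADME assay on microsomes from liver (Homo sapiens) for metabolic stability, read by LC-MS, using NADPH, tested at 5 uM (on this read-out higher numbers stand for a longer-lived compound and lower numbers for a shorter-lived compound), compound 1 `Cc1cc(S(=O)(=O)/N=C(\N)n2nccc2-c2ccccc2)c(SCc2cccc(Cl)c2)cc1Cl` gives 0.309 h, the highest of the three numbers measured so far. Compound 2 `Cc1cc(-c2ccccc2)n(/C(N)=N/S(=O)(=O)c2cc(C)c(Cl)cc2SCc2cccc(Cl)c2)n1` gives 0.205 h and compound 3 `Cc1cc(-c2ccccc2)n(/C(N)=N/S(=O)(=O)c2cc(C)c(Cl)cc2SCc2ccc(Cl)cc2)n1` gives 0.24 h; both gaps to compound 1 sit within the scatter, as do the steps of a 1.5-fold lower number from compound 1 to compound 2 (0.18 log units; within the scatter) and a 1.2-fold higher number from compound 2 to compound 3 (0.07 log units; within the scatter). Compound 4 `Cc1cc(S(=O)(=O)/N=C(\N)n2nccc2-c2ccccc2)c(SCc2ccccc2C(F)(F)F)cc1Cl` differs from compound 1 by 2-(trifluoromethyl)phenyl in place of 3-chlorophenyl on a saturated chain carbon bound to a sulfur. Among the compounds with values here, the only measured step at that position, a swap of one chlorophenyl for another, left no mark beyond the scatter; no measured pair covers a trifluoromethyl group. Because the step of a 1.2-fold higher number from compound 2 to compound 3 (0.07 log units; within the scatter) stayed within the scatter, no step beyond the scatter is expected for compound 4 a 1.0-fold lower number from compound 1 to compound 4 (0.01 log units; within the scatter). Compound 4 is estimated at 0.3 h, between 0.15 h and 0.6 h.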

Compound 4, half-life: 0.15 h
For compound 4 the middle estimate is 2.0-fold (0.30 log units) above the measured one; low and high end bracket the measured number.
By their numbers in this assay, from the lowest: compounds 4, 2, 3 and 1 (each within the scatter of the next, the first and the last beyond it).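

At the group on a saturated chain carbon bound to a sulfur, this assay now gives a step beyond the scatter: a 2.1-fold lower number from compound 1 to compound 4 (0.31 log units; beyond the scatter) with 2-(trifluoromethyl)phenyl in place of 3-chlorophenyl. The earlier swap here, a 1.2-fold higher number from compound 2 to compound 3 (0.07 log units; within the scatter), stayed within the scatter, so this position can move the half-life, if only modestly. No measurement at hand accounts for the shorter half-life.

Still open, from the compounds shown here alone, is whether the step follows the trifluoromethyl group or the different substitution of the phenyl ring, since the change alters both. Going by these compounds, how an amine or a carboxylic acid on that phenyl ring would read also remains open.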